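Methoxy in Place of Methyl: Expected Cell Tolerance

The source may report more compounds than this note shows. Statements on the series, on what has been measured and on what is new or still open speak of the compounds shown alone.

Measured so far:
compound 1, `Cc1ccc2[nH]c(=O)c(CN(Cc3ccco3)C(=O)c3ccc(Br)cc3)cc2c1`: > 55400 nM
compound 2, `Cc1ccc2[nH]c(=O)c(CN(Cc3cccs3)C(=O)C3CCCCC3)cc2c1`: > 63400 nM

In an ADME assay on MT2 cells (Homo sapiens) for cytotoxicity, read by XTT assay, with a stated time of 4 days (a higher number here means that more compound is tolerated, a lower number that less compound is tolerated), compound 1 gives > 55400 nM, which is a limit of the assay rather than a number. In this assay compound 2 gives > 63400 nM, likewise a limit. Compound 2 thus stands at the edge of what this assay can report, and since both values shown are limits, neither compound can be ranked against the other: the limit of > 55400 nM in this assay, at which 1 of the 2 values shown sits, and the limit of > 63400 nM in this assay, at which 1 of the 2 values shown sits, together describe everything known.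

Compound 3, `COc1ccc2[nH]c(=O)c(CN(Cc3cccs3)C(=O)C3CCCCC3)cc2c1`, differs from compound 2 by one change: methoxy in place of methyl on an aromatic carbon. Going by the values given here, no measured pair carries this change, so its effect is not known from the data. A step from compound 2 to compound 3 is expected to be none beyond the scatter in this assay. Compound 3 is expected to give about 65000 nM, with a range from 30000 nM to 130000 nM. The expected step that the limit leaves unreadable from compound 2 to compound 3 is small, and a limit rather than a number is the most likely report.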

Compound 3, half-maximal cytotoxic concentration: > 48000 nM
Compound 3 gave a limit, no number; the forecaster's own chance of this, stated with the estimate: 85%; the middle value is on the limit's open side.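

Compound 2 and compound 3 both give limits, not numbers, in this assay. Going by these compounds alone, no step between compound 2 and compound 3 can be read. The compounds shown leave open the concentration at which any of them becomes toxic to these cells, and whether methoxy in place of methyl alters it.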